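Diaryl urea series: swapping the aryl group on compound 3

The source may report more compounds than this note shows. Statements on the series, on what has been measured and on what is new or still open speak of the compounds shown alone.

Measured so far in a functional assay on NCI-H460 cells (Homo sapiens) for antiproliferative activity, read by MTT assay, with a stated time of 72 h; on this read-out lower numbers stand for stronger inhibition and higher numbers for weaker inhibition:
compound 1 `CN(C)CCn1cnnc1-c1cc(Oc2ccc(NC(=O)Nc3ccc(F)c(F)c3)cc2F)ccn1`: 9050 nM
compound 2 `CCN(CC)CCn1cnnc1-c1cc(Oc2ccc(NC(=O)Nc3ccc(F)c(F)c3)cc2F)ccn1`: 14900 nM
compound 3 `CN(C)CCCn1cnnc1-c1cc(Oc2ccc(NC(=O)Nc3cccc(C(F)(F)F)c3)cc2F)ccn1`: 1790 nM

Compound 3 stands lowest of the three numbers; compound 1 is nearest and compound 2 furthest, both beyond the scatter. For the measured compounds named here, the only single-site step measured so far, a 1.6-fold higher number from compound 1 to compound 2 (0.22 log units; within the scatter), concerns the amine end of the molecule and does not touch the change under consideration. Compound 4 `CN(C)CCCn1cnnc1-c1cc(Oc2ccc(NC(=O)Nc3ccc(F)c(F)c3)cc2F)ccn1` differs from compound 3 by 3,4-difluorophenyl in place of 3-(trifluoromethyl)phenyl on an amide-type nitrogen. Going by the values given here, compounds 1 and 3 differ in more than one place, so their values cannot be read as this step alone; they show only that the compound carrying the trifluoromethylphenyl gives the lower number. Among the compounds with values here, no measured step bears directly on the change. A move towards compound 1, moderate and upwards, is therefore expected: compound 4 is estimated at 5000 nM (range 1800 nM to 14000 nM), the expected step being a 2.8-fold higher number from compound 3 to compound 4 (0.45 log units; beyond the scatter).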

Compound 4, half-maximal inhibitory concentration: 1080 nM
The estimate for compound 4 lay 4.6-fold (0.67 log units) above the measured number, and the stated range ends above it.
By their numbers in this assay, from the lowest: compounds 4 and 3 (each within the scatter of the next); then compounds 1 and 2 (each within the scatter of the next).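

In this assay, 3,4-difluorophenyl in place of 3-(trifluoromethyl)phenyl on the amide-type nitrogen gives (a 1.7-fold lower number from compound 3 to compound 4 (0.22 log units; within the scatter)), so this read-out does not separate these two aryl groups when the rest of the molecule is held constant. The amine end, earlier seen only through a step within the scatter, now gives steps beyond it: (dimethylamino)methyl in place of dimethylamino gives (an 8.4-fold lower number from compound 1 to compound 4 (0.92 log units; beyond the scatter)), and (dimethylamino)methyl in place of diethylamino gives (a 14-fold lower number from compound 2 to compound 4 (1.14 log units; beyond the scatter)). No measurement at hand accounts for either the flat aryl step or the larger amine-chain steps.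

The compounds shown leave open whether an unsubstituted phenyl or a 4-chlorophenyl on the same nitrogen would also fall within the scatter of these two aryl groups. They also leave open whether a longer chain or a terminal morpholine would extend the amine-chain steps.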